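A small chain change and its expected effect on inhibition

This account rests on a few compounds, and the source may have more. Where it says the series, first, only, none or still open, it means among the compounds named here.

Measured in an assay on SW1353 cells (Homo sapiens) for inhibition, read by a luciferase reporter, with stated times of 30 min and 8 h; on this read-out higher numbers stand for weaker inhibition and lower numbers for stronger inhibition:
- Compound 1 `O=c1oc2ccccc2n1CCCCCN1CCN(CCCCCn2c(=O)oc3ccccc32)CC1` gives 3430 nM
- Compound 2 `O=c1oc2ccccc2n1CCCCCCN1CCN(CCCCn2c(=O)oc3ccccc32)CC1` gives 1240 nM

Of these two, compound 2 has the lower number and so the stronger inhibition, and its gap to compound 1 lies beyond the usual scatter. Compound 3 `O=c1oc2ccccc2n1CCCCCCN1CCN(CCCCCn2c(=O)oc3ccccc32)CC1` differs from compound 2 in one place: a group of 11 heavy atoms (8 carbon, 1 nitrogen, 2 oxygen; one five-membered aromatic ring with 2 hetero atoms, one six-membered aromatic ring of carbon only) in place of a group of 10 heavy atoms (7 carbon, 1 nitrogen, 2 oxygen; one five-membered aromatic ring with 2 hetero atoms, one six-membered aromatic ring of carbon only), on a saturated chain carbon, four bonds along the chain from an amine nitrogen in a ring. The change sits on a saturated chain carbon, four bonds along the chain from an amine nitrogen in a ring. Among the compounds with values here, no measured pair shows this change alone, so the guide is thin. With compound 2 at 1240 nM and compound 1 at 3430 nM, a number inside that span seems likeliest. In this assay a small rise, towards weaker inhibition and not beyond the scatter, is expected. The estimated change is a 1.6-fold higher number from compound 2 to compound 3 (0.21 log units; within the scatter). For compound 3 the estimate is 2000 nM, with an expected range of 700 nM to 5000 nM.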

Compound 3, half-maximal inhibitory concentration: 1400 nM
Estimate against measurement, compound 3: 1.4-fold (0.15 log units) above; measured number inside the range.
By their numbers in this assay, from the lowest: compounds 2 and 3 (each within the scatter of the next); then compound 1.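

In this assay, placing the group of 11 heavy atoms where the group of 10 heavy atoms stood, on a saturated chain carbon four bonds along the chain from an amine nitrogen in a ring, gives a 1.1-fold higher number from compound 2 to compound 3 (0.05 log units; within the scatter) and so no change that can be told from scatter. The same exchange, on a saturated chain carbon five bonds along the chain from an amine nitrogen in a ring, gives a 2.5-fold lower number from compound 1 to compound 3 (0.39 log units; beyond the scatter) as a modest gain in inhibition, so its effect differs between these two places in this small set. Nothing measured here explains that difference.

Going by these compounds, it remains open whether a still longer chain at either place would keep or lose this inhibition. Also untested among these compounds is the effect of ending a chain in an amine or a carboxylic acid.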